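The compounds below may be only part of what the source reports. "The series", "measured", "known", "first", "only" and "open" are said of these compounds alone.

Series notes. In an assay for positive allosteric modulation of metabotropic glutamate receptor 3 (Rattus norvegicus) (a lower number here means that less compound is needed, a higher number that more compound is needed for the effect), compound 1 `COc1ccc(C(=O)O)cc1OC[C@H](C)Oc1ccc(C(=O)CC(C)(C)C)c(O)c1C` gives 3820 nM. Compound 2 `Cc1c(OC[C@H](C)COc2ccc(F)c(C(=O)O)c2)ccc(C(=O)CC(C)(C)C)c1O` gives 651 nM in this assay, and compound 3 `Cc1c(OC[C@@H](C)COc2ccc(F)c(C(=O)O)c2)ccc(C(=O)CC(C)(C)C)c1O` gives 1180 nM. For the measured compounds named here, the one single-point step measured so far, a 1.8-fold higher number from compound 2 to compound 3 (0.26 log units; within the scatter), runs between the two compounds that differ only in configuration as drawn (the fact that compounds 2 and 3 differ only in the configuration as drawn), and it stays within the scatter. Compound 3 therefore stands second highest of the three numbers: nearest to compound 2, within the scatter, and furthest from compound 1, whose higher number lies beyond the scatter.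

Compound 4 `COc1cccc(OC[C@H](C)COc2ccc(C(=O)CC(C)(C)C)c(O)c2C)c1` is the next one to go into this assay. The change from compound 3 is 3-methoxyphenyl in place of 3-carboxy-4-fluorophenyl on an oxygen on a saturated carbon. Going by the values given here, no measured step bears on this change: the only step recorded so far concerns configuration at a saturated chain carbon and leaves the group on the oxygen on a saturated carbon untouched, and compounds 1, 2 and 3 all carry a carboxy group that compound 4 lacks. The size and direction of a 5.1-fold higher number from compound 3 to compound 4 (0.71 log units; beyond the scatter) can therefore only be expected with wide bounds. Compound 4 is estimated at 6000 nM, with a range from 1500 nM to 25000 nM.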

Compound 4, half-maximal effective concentration: "not active" (no number reported)
Compound 4: no number reported, and the estimate cannot be compared.
By their numbers in this assay, from the lowest: compounds 2 and 3 (each within the scatter of the next); then compound 1.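

In this assay, for the compounds shown here, compound 4 is reported as not active, without a number, so no step from compound 3 to compound 4 can be read. The compounds shown leave open how 3-methoxyphenyl compares numerically with 3-carboxy-4-fluorophenyl on this oxygen, and which part of that change matters. Nothing on record bears on the result for compound 4.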